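From an Amide to a Carbamoyl Link: Expected Cell Toxicity

This account rests on a few compounds, and the source may have more. Where it says the series, first, only, none or still open, it means among the compounds named here.

Compound 1 `COc1cc(-c2nn(-c3cccc(NC(=O)c4cccc(C(F)(F)F)c4)c3)cc2-c2ccncc2)ccc1Cl` was tested in a functional assay on IGROV-1 cells (Homo sapiens) for inhibition, read by sulforhodamine B assay, with a stated time of 48 h; on this read-out higher numbers stand for lower toxicity in this test and lower numbers for higher toxicity in this test. In this assay compound 1 gives only a limit, > 50000 nM. Compound 2 `O=C(Nc1cccc(-n2cc(-c3ccncc3)c(-c3ccc(Cl)c(O)c3)n2)c1)Nc1ccc(Cl)c(C(F)(F)F)c1` likewise reaches only a limit in this assay, > 32500 nM. Going by the values given here, compound 1 thus stands at a limit, and the one further value shown is a limit too, so the two cannot be ordered against each other; both simply show low toxicity on this read-out. Compound 3 `COc1cc(-c2nn(-c3cccc(NC(=O)Nc4ccc(Cl)c(Cl)c4)c3)cc2-c2ccncc2)ccc1Cl` has not yet been measured in this assay. It differs from compound 1 in a single place: (3,4-dichlorophenyl)amino in place of 3-(trifluoromethyl)phenyl on a carbonyl carbon. The same difference, cut one bond further out, reads (3-(trifluoromethyl)phenyl)carbonyl to (3,4-dichlorophenyl)carbamoyl. Because compound 1 sits at the limit of > 50000 nM in this assay, at which 1 of the 2 values shown sits, and compound 2 at the limit of > 32500 nM in this assay, at which 1 of the 2 values shown sits, no change beyond the scatter is expected. The step is estimated as a number no higher from compound 1 to compound 3 (the limit leaves the size open). Compound 3 is expected to give about 50000 nM in this assay, within a range from 20000 nM to 100000 nM, most likely reported as a limit once more.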

Compound 3, concentration lethal to 50% of the cells: > 50000 nM
Compound 3: only a limit was reported; the forecaster's own chance of this, stated with the estimate: 75%; the middle value lies on the limit itself.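

Compound 1 and compound 3 both stop at the same limit of the assay, so no step can be read between them: the limit of > 50000 nM in this assay, at which 2 of the 3 values shown sit.

The compounds shown leave open whether (3,4-dichlorophenyl)amino in place of 3-(trifluoromethyl)phenyl changes cell toxicity at all.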